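This account rests on a few compounds, and the source may have more. Where it says the series, first, only, none or still open, it means among the compounds named here.

Measured in an ADME assay on L1210/0 cells (Mus musculus) for cytotoxicity, with a stated time of 48 h; a higher number here means a weaker inhibitor, a lower number a stronger inhibitor:
- compound 1 `O=c1[nH]c(=O)n([C@H]2C[C@H](O)[C@@H](CO)O2)cc1C#Cc1ccccc1`: > 200000 nM (a limit)
- compound 2 `CCCCCCc1cn([C@H]2C[C@H](O)[C@@H](CO)O2)c(=O)[nH]c1=O`: > 200000 nM (a limit)

Compound 2 stands only at a limit, with no measured number behind it. For the measured compounds named here, the same holds across the series so far: the limit of > 200000 nM in this assay, at which 2 of the 2 values shown sit.

The next step leads to compound 3 `O=c1[nH]c(=O)n([C@H]2C[C@H](O)[C@@H](CO)O2)cc1O`, with hydroxy in place of hexyl on an aromatic carbon. Going by the values given here, only one measured step bears on it, a step that the two limits leave unreadable from compound 1 to compound 2, which gives no size to carry forward. That step also exchanges one large group for another, so the series holds no measured case of a group as small as hydroxy.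

The data therefore set no firm size or direction for the change in this assay. Any shift is tentatively expected towards a stronger inhibitor, and compound 3 may well report only a limit too. The expected at least 2.0-fold lower number from compound 2 to compound 3 (0.30 log units; that floor lies within the scatter) is a loose estimate. For compound 3 the estimated value is 100000 nM, with an expected range of 10000 nM to 300000 nM.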

Compound 3, half-maximal inhibitory concentration: > 200000 nM
Compound 3 gave a limit, no number; the forecaster's own chance of this, stated with the estimate: 45%; middle value at least 2.0-fold (0.30 log units) from the limit.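

In this assay compound 3 gives > 200000 nM, a limit and not a number. No new step can be read among compound 1, compound 2 and compound 3, and the series stands at a single limit: the limit of > 200000 nM in this assay, at which 3 of the 3 values shown sit.

The compounds shown leave open whether the group on this aromatic carbon changes the read-out at all, and in which direction.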